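The compounds below may be only part of what the source reports. "The series", "measured", "known", "first", "only" and "open" are said of these compounds alone.

Compound 2 `C=CC1=C(C(=O)NCc2ccc(C)cc2)C(c2ccc(OC)cc2)OC1` is the only one of the three measured compounds to give a number in a functional assay on HeLa cells (Homo sapiens) for cytotoxicity, read by MTT assay, with a stated time of 24 h; a lower number here means a stronger inhibitor, a higher number a weaker inhibitor: compound 2 gives 15900 nM. Compound 1 `C=CC1=C(C(=O)NCCC)C(c2ccc(OC)c(OC)c2)OC1` gives a limit in this assay, > 100000 nM. Compound 3 `C=CC1=C(C(=O)NCc2ccc(C)cc2)C(c2ccc(F)cc2)OC1` likewise gives a limit, > 100000 nM. Going by the values given here, the single measured step, an at least 6.2-fold higher number from compound 2 to compound 3 (0.79 log units; beyond the scatter), changes a group on the aromatic ring and not the amide chain. Compound 4 `C=CC1=C(C(=O)NCCC)C(c2ccc(OC)cc2)OC1` differs from compound 2 by ethyl in place of 4-methylphenyl on a saturated chain carbon bound to an amide-type nitrogen. Among the compounds with values here, no measured step covers this change on its own, but compound 1, which carries the same propyl chain, sits at the limit of > 100000 nM in this assay, at which 2 of the 3 values shown sit. A rise in the number is therefore expected, a 3.1-fold higher number from compound 2 to compound 4 (0.50 log units; beyond the scatter). Compound 4 is estimated at 50000 nM, within a range from 12000 nM to 200000 nM.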

Compound 4, half-maximal inhibitory concentration: 14000 nM
Compound 4: middle estimate off by 3.6-fold (0.55 log units), on the high side; measured number inside the range.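

In this assay, the exchange of 4-methylbenzyl for propyl gives a 1.1-fold lower number from compound 2 to compound 4 (0.06 log units; within the scatter), so these two amide chains cannot be told apart here. With propyl kept, the aromatic ring carries the difference: removing one methoxy gives an at least 7.1-fold lower number from compound 1 to compound 4 (0.85 log units; beyond the scatter). The poor reading of compound 1 therefore does not come from the propyl chain alone, and that reading is a limit, not a number: the limit of > 100000 nM in this assay, at which 2 of the 4 values shown sit.

Going by these compounds, what a longer chain or a chain ending in an amine would do at this position stays open. So does whether a carboxylic acid there would keep the number near those of compound 2 and compound 4.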